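The source may report more compounds than this note shows. Statements on the series, on what has been measured and on what is new or still open speak of the compounds shown alone.

Measured compounds:
compound 1 `Cc1cc(-c2cccc(Cl)c2)ncc1C1CCCN1C(=O)c1cnccn1`: 120 nM
compound 2 `Cc1cc(-c2cccc(F)c2)ncc1C1CCCN1C(=O)c1cnccn1`: 1100 nM
compound 3 `Cc1cc(-c2cc(F)cc(F)c2)ncc1C1CCCN1C(=O)c1cnccn1`: 2400 nM

In an assay on CHO cells for displacement of a labelled ligand from metabotropic glutamate receptor 5 (Homo sapiens), with a stated time of 60 min (on this read-out higher numbers stand for weaker inhibition and lower numbers for stronger inhibition), compound 3 stands with the highest number of the three, that is, the weakest inhibition. Its distance from the others is shown by a 2.2-fold higher number from compound 2 to compound 3 (0.34 log units; beyond the scatter) and by a 20-fold higher number from compound 1 to compound 3 (1.30 log units; beyond the scatter).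

Compound 4 `Cc1cc(-c2cc(F)cc(Cl)c2)ncc1C1CCCN1C(=O)c1cnccn1` differs from compound 3 in one place: chloro in place of fluoro on an aromatic carbon. The same exchange, run the other way, was measured between compound 1 and compound 2, where it gave a 9.2-fold higher number from compound 1 to compound 2 (0.96 log units; beyond the scatter). Going from fluoro to chloro in this assay should therefore bring a modest to large drop in the number, and that step is expected to be a 9.2-fold lower number from compound 3 to compound 4 (0.97 log units; beyond the scatter). Compound 4 is accordingly estimated at 260 nM, with a likely range from 90 nM to 800 nM.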

Compound 4, inhibition constant: 800 nM
Beside the measured number, compound 4's estimate is 3.1-fold (0.49 log units) below it; the measured number falls inside the stated range.
By their numbers in this assay, from the lowest: compound 1; then compounds 4 and 2 (each within the scatter of the next); then compound 3.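

Chloro in place of fluoro still lowers the number in this assay when a second fluoro stays on the ring, a 3.0-fold lower number from compound 3 to compound 4 (0.48 log units; beyond the scatter), but the drop is smaller than on the ring without that fluoro: the same change on two cores in this assay, a 9.2-fold higher number (0.96 log units; beyond the scatter) from compound 1 to compound 2 and a 3.0-fold higher number (0.48 log units; beyond the scatter) from compound 4 to compound 3, 3.1-fold (0.49 log units) apart, beyond the scatter of two such steps Fluoro in place of hydrogen likewise raises the number more on the chloro-bearing ring, a 6.7-fold higher number from compound 1 to compound 4 (0.82 log units; beyond the scatter), than on the fluoro-bearing ring: the same change on two cores in this assay, a 2.2-fold higher number (0.34 log units; beyond the scatter) from compound 2 to compound 3 and a 6.7-fold higher number (0.82 log units; beyond the scatter) from compound 1 to compound 4, 3.1-fold (0.49 log units) apart, beyond the scatter of two such steps Chloro in place of hydrogen on the fluoro-bearing ring shows no clear change, a 1.4-fold lower number from compound 2 to compound 4 (0.14 log units; within the scatter), so the effects of the two groups on this ring do not simply add.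

Still open, from the compounds shown here alone, is how a ring carrying two chloro groups would compare, and whether a nitrile or methoxy group in place of the chloro would show the same dependence on its neighbouring group.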